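A reversed, shortened amide on the cyclopentane ring

A few compounds are considered here, and "the series" means these few. Any claim that something is new, unique, unknown or untested is made for them only; others in the source may bear on it.

Measured compounds:
- compound 1 `Brc1nn(-c2ccc3ncccc3c2)c2nc(Nc3cnn(C4CCNCC4)c3)ncc12`: 3 nM
- compound 2 `COCCC(=O)N[C@@H]1CC[C@@H](Nc2ncc3c(Br)nn(-c4ccc5ncccc5c4)c3n2)C1`: 74 nM

In an assay on isolated protein for inhibition of eIF-2-alpha kinase GCN2 (Homo sapiens) (a lower number here means a stronger inhibitor, a higher number a weaker inhibitor), compound 1 gives 3 nM. Compound 2 carries a substituted cyclopentane in place of the piperidinyl-pyrazole of compound 1; in this assay compound 2 gives 74 nM. For the measured compounds named here, of the two numbers, compound 2 stands at the higher one, and its gap to compound 1 lies well beyond the scatter of repeated measurements; since the two differ in more than one place, no single step can be drawn between them.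

Compound 3 `CNC(=O)[C@@H]1CC[C@@H](Nc2ncc3c(Br)nn(-c4ccc5ncccc5c4)c3n2)C1` has not yet been measured in this assay. It differs from compound 2 in one place: methylcarbamoyl in place of ((2-methoxyethyl)carbonyl)amino on a saturated ring carbon. The amide is thus turned around and trimmed, while the shared core and the rest of the molecule stay as in compound 2. Going by the values given here, no measured pair shows what such a change does here, so the expectation rests on compound 2 alone and is wide. The step from compound 2 to compound 3 is expected to be small, a 1.2-fold lower number from compound 2 to compound 3 (0.09 log units; within the scatter), not clearly beyond the scatter in either direction. For compound 3 a value of about 60 nM is expected in this assay, with a range from 15 nM to 250 nM.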

Compound 3, half-maximal inhibitory concentration: 21 nM
The estimate for compound 3 lay 2.9-fold (0.46 log units) above the measured number; low and high end bracket the measured number.
By their numbers in this assay, from the lowest: compound 1; then compound 3; then compound 2.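

In this assay, putting methylcarbamoyl in place of ((2-methoxyethyl)carbonyl)amino on this saturated ring carbon gives a 3.5-fold lower number from compound 2 to compound 3 (0.55 log units; beyond the scatter), a modest step. This shows that the position, two ring bonds from the ring atom that bears a large group, does not depend on the larger group that leaves: with the amide turned around and the substituent cut from 7 heavy atoms to 4, the number moves down rather than up, and the hydrogen-bond donor count stays the same. Nothing shown here gives a measured reason for the step.

The swap turns the amide around and shortens the group in one move, so the compounds shown do not separate what each of these contributes to the step. Going by these compounds, it also remains open how this assay would respond at the same ring carbon to a primary amine, to a carboxylic acid, or to a longer chain on the amide nitrogen of the methylcarbamoyl group.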